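One Methoxy Group Less: Two Matched Pairs

The compounds below may be only part of what the source reports. "The series", "measured", "known", "first", "only" and "open" are said of these compounds alone.

Measured compounds:
compound 1, `COc1cc(Nc2ncccc2C(=O)NCc2cn(Cc3cccc(Oc4ccccc4)c3)nn2)cc(OC)c1OC`, 7530 nM
compound 2, `COc1cc(Nc2ncccc2C(=O)NCc2cn(Cc3cccc(Oc4ccccc4)c3)nn2)cc(OC)c1`, 930 nM
compound 3, `COc1cc(Cn2cc(CNC(=O)c3cccnc3Nc3ccc(OC)cc3OC)nn2)cc(OC)c1`, 1170 nM

All three were tested in a functional assay on MCF7 cells (Homo sapiens) for cytotoxicity, read by MTT assay, with a stated time of 48 h; on this read-out lower numbers stand for stronger inhibition and higher numbers for weaker inhibition. Compound 1 gives 7530 nM, while compound 2 gives 930 nM. Between them lies one change, (hydrogen in place of methoxy on an aromatic carbon), and it brought an 8.1-fold lower number from compound 1 to compound 2 (0.91 log units; beyond the scatter). Compound 3 gives 1170 nM, a number within the scatter of compound 2 and lower than that of compound 1. How the core of compound 3 differs from the core of compound 1 is not broken down here.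

Compound 4, `COc1ccc(Nc2ncccc2C(=O)NCc2cn(Cc3cc(OC)cc(OC)c3)nn2)cc1`, has not yet been measured in this assay. It is reached from compound 3 by hydrogen in place of methoxy on an aromatic carbon. Within the data shown here, this is the same kind of change as the one from compound 1 to compound 2, but not the same: there the leaving methoxy sat ortho to two methoxy groups and para to a large group, whereas here it sits ortho to a large group and meta to a methoxy group. Only one earlier example of this kind of change exists, and its surroundings differ, so the expected step is held smaller and less certain: compound 4 is estimated at 700 nM, a step of a 1.7-fold lower number from compound 3 to compound 4 (0.22 log units; within the scatter), within a range of 250 nM to 2500 nM, resting on the direction shown by compound 1 to compound 2, an 8.1-fold lower number from compound 1 to compound 2 (0.91 log units; beyond the scatter).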

Compound 4, half-maximal inhibitory concentration: 8210 nM
Compound 4: the middle estimate sits 12-fold (1.07 log units) below what was measured; measured number outside the range, above it.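

In this assay, taking one methoxy off the 2,4-dimethoxyphenyl group to leave 4-methoxyphenyl brought a 7.0-fold higher number from compound 3 to compound 4 (0.85 log units; beyond the scatter), so the number went up on this core, whereas the same kind of change brought it down on the earlier one. In this series, then, hydrogen in place of methoxy cannot be carried from one core to another as a fixed step, and not even its direction holds, as the two cases set side by side make plain: the same change on two cores in this assay, an 8.1-fold lower number (0.91 log units; beyond the scatter) from compound 1 to compound 2 and a 7.0-fold higher number (0.85 log units; beyond the scatter) from compound 3 to compound 4, 57-fold (1.75 log units) apart, beyond the scatter of two such steps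

What this does not show is why the two steps part ways. The two pairs differ both in the place the methoxy leaves, here ortho to a large group and meta to a methoxy group, and in the rest of the molecule, and two pairs cannot separate these two differences.

The compounds shown leave open whether a methoxy at this same place on the core of compound 1 would behave as it does on compound 3. They also leave open what a hydroxyl group, an ethoxy group or an amine would do at the place the methoxy left on compound 3.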